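The source may hold more compounds than are shown below. What is called first, only, known or untested is meant among the compounds shown, and "the series" means these compounds.

Measured so far:
- compound 1, `CC(=O)N1CCC(c2nc(NCc3ccccn3)ncc2-c2cc(C)no2)CC1`: 221000 nM in a physicochemical assay for solubility, with a stated time of 24 h, at pH 3; on this read-out higher numbers stand for higher solubility and lower numbers for lower solubility
- compound 2, `CC(=O)N1CCC(c2nc(NCc3cccnc3)ncc2-c2cc(C)no2)CC1`: 238000 nM in this assay
- compound 3, `Cc1cc(-c2cnc(NCc3cccnc3)nc2-c2ccc(C)s2)on1`: 1000 nM in this assay

Compound 4, `Cc1cc(-c2cnc(NCc3ccccn3)nc2-c2ccc(C)s2)on1`, has not yet been measured. It differs from compound 3 in one place only: pyridin-2-yl in place of pyridin-3-yl on a saturated chain carbon bound to a nitrogen on an aromatic ring. The very same change, at the same place, connects two compounds that are already measured: compound 1 differs from compound 2 by pyridin-2-yl in place of pyridin-3-yl on a saturated chain carbon bound to a nitrogen on an aromatic ring, and that step gave a 1.1-fold lower number from compound 2 to compound 1 (0.03 log units; within the scatter). Compounds 1 and 2 share one core, compounds 3 and 4 another; the two cores differ as compound 2 and compound 3 do: 5-methylthiophen-2-yl in place of 1-acetylpiperidin-4-yl on an aromatic carbon. That change gave a 240-fold lower number from compound 2 to compound 3 (2.38 log units; beyond the scatter), and compound 3 stands far below compounds 1 and 2. Compound 4 is expected to start from that low level because compound 3 gives 1000 nM. For compound 4 the expected step is a 1.1-fold lower number from compound 3 to compound 4 (0.02 log units; within the scatter), small, resting on the earlier pair because the same swap gave a 1.1-fold lower number from compound 2 to compound 1 (0.03 log units; within the scatter). Compound 4 is therefore estimated at 950 nM, with a likely range from 400 nM to 2500 nM.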

Compound 4, solubility: 1000 nM
Beside the measured number, compound 4's estimate is 1.1-fold (0.02 log units) below it; the range from low to high includes it.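

In this assay, putting pyridin-2-yl in place of pyridin-3-yl on the core of compound 3 gives no change at the digits printed from compound 3 to compound 4 (within the scatter) and on the core of compound 2 gave a 1.1-fold lower number from compound 2 to compound 1 (0.03 log units; within the scatter). The swap therefore made no change beyond the scatter on either core, although the numbers on the two cores lie far apart, as the core step shows with a 220-fold lower number from compound 1 to compound 4 (2.34 log units; beyond the scatter) and with the change marked large. This is only two pairs, so it shows that the result carried from one core to the other here, not that it would hold on a third core, and nothing shown accounts for either the flat swap or the large core step.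

The compounds shown leave open what pyridin-4-yl or a plain phenyl would give on the same saturated chain carbon. They also leave open whether a carboxylic acid or a free amine, in place of 1-acetylpiperidin-4-yl on the aromatic carbon, would give a number nearer to one core or the other.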